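The compounds below may be only part of what the source reports. "The series", "measured", "known", "first", "only" and "open" are said of these compounds alone.

Compound 1 `COc1ccc(-c2c(Nc3cc(OC)c(OC)c(OC)c3)c3ccc(OC)cc3oc2=O)cc1` and compound 3 `COc1ccc(-c2c(Nc3cc(OC)c(OC)c(OC)c3)c3ccc(O)cc3oc2=O)cc1` share one core and differ at a single point. In a functional assay on HepG2 cells (Homo sapiens) for antiproliferative activity, read by MTT assay, with a stated time of 48 h (on this read-out higher numbers stand for weaker inhibition and lower numbers for stronger inhibition), compound 1 gives 84300 nM. In this assay compound 3 gives 49700 nM. The change between them is hydrogen in place of methyl on an oxygen on an aromatic ring and it produced a 1.7-fold lower number from compound 1 to compound 3 (0.23 log units; within the scatter), so the two values cannot be told apart.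

Compound 2 `COc1ccc(-c2c(Nc3ccc(F)cc3)c3ccc(OC)cc3oc2=O)cc1` has a core that differs from that of compound 1 in a way that is not broken down here. In this assay compound 2 gives > 100000 nM, which is a limit of the assay rather than a number; this rests on (the limit of > 100000 nM in this assay, at which 1 of the 3 values shown sits).

Compound 4 `COc1ccc(-c2c(Nc3ccc(F)cc3)c3ccc(O)cc3oc2=O)cc1` is not yet measured. Among the compounds with values here, it differs from compound 2 by hydrogen in place of methyl on an oxygen on an aromatic ring, the same change, at the same kind of place, as the one from compound 1 to compound 3. Since that earlier step was a 1.7-fold lower number from compound 1 to compound 3 (0.23 log units; within the scatter), the step from compound 2 to compound 4 is expected to be of similar small size, an at least 1.2-fold lower number from compound 2 to compound 4 (0.09 log units; that floor lies within the scatter). Compound 4 is therefore estimated at 80000 nM, with a range from 30000 nM to 200000 nM, and the assay may again report only a limit.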

Compound 4, half-maximal inhibitory concentration: 65600 nM
Compound 4: the middle estimate sits 1.2-fold (0.09 log units) above what was measured, and the stated range covers the measured number.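

In this assay compound 2 gives > 100000 nM, which is a limit of the assay and not a number. Going from methoxy to hydroxy on this core can therefore be read only as a floor, an at least 1.5-fold lower number from compound 2 to compound 4 (0.18 log units; that floor lies within the scatter), so the true step could be larger, and on neither core is the change shown to stand clear of the scatter. Set side by side, the two steps fit a change that carries over from one core to the other, but they do not prove that it does, and any real difference between the cores remains hidden: the same change on two cores in this assay, a 1.7-fold lower number (0.23 log units; within the scatter) from compound 1 to compound 3 and an at least 1.5-fold lower number (0.18 log units; that floor lies within the scatter) from compound 2 to compound 4; the limit leaves it open whether they differ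

The compounds shown carry only methoxy or hydroxy at this place on the aromatic ring, so the effect there of an amine, a carboxylic acid or a longer chain such as ethoxy stays open. Also open, going by these compounds, are the exact size of the step on the core of compound 2 and whether the change would behave the same way on any core beyond these two.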